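This account rests on a few compounds, and the source may have more. Where it says the series, first, only, none or still open, it means among the compounds named here.

Compound 2 `CC(C)(O)Cn1cc(-c2ccc(F)cc2)c(=O)c2c(Nc3ccc(Oc4ccnc(NC(=O)C5CC5)c4)c(F)c3)nccc21` gives -2.6% in a functional assay on HT-29 cells (Homo sapiens) for antiproliferative activity, read by MTT assay, with a stated time of 72 h, tested at 10 uM (on this read-out higher numbers stand for more inhibition at the one concentration tested (going by the name of the read-out) and lower numbers for less inhibition), the lowest of the three values at hand: compound 1 `Cn1cc(-c2ccc(F)cc2)c(=O)c2c(Nc3ccc(Oc4ccnc(NC(=O)C5CC5)c4)c(F)c3)nccc21` gives 24.8% and compound 3 `Nc1nccc(Oc2ccc(Nc3nccc4[nH]cc(-c5ccc(F)cc5)c(=O)c34)cc2F)c1Cl` gives 56.2% in this assay. Compound 4 `CCn1cc(-c2ccc(F)cc2)c(=O)c2c(Nc3ccc(Oc4ccnc(NC(=O)C5CC5)c4)c(F)c3)nccc21` differs from compound 2 by methyl in place of 1-hydroxy-1-methylethyl on a saturated chain carbon bound to an aromatic nitrogen. Going by the values given here, the one measured step that bears on this change is a number 27.4 percentage points lower from compound 1 to compound 2 (beyond the scatter), which runs in the opposite direction to the present substitution. Removing the 1-hydroxy-1-methylethyl group is therefore expected to recover much of that loss, with compound 4 landing close to compound 1 rather than compound 2. Against compound 2 this amounts, in the estimate, to a number 22.6 percentage points higher from compound 2 to compound 4 (beyond the scatter). Compound 4 is estimated at 20%, between 5% and 35%.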

Compound 4, a percentage reported as inhibition, at one concentration (the size of the read-out at that concentration, not a potency): 15.8%
Compound 4: the middle estimate sits 4.2 percentage points above what was measured, and the stated range covers the measured number.
By their numbers in this assay, from the lowest: compound 2; then compounds 4 and 1 (each within the scatter of the next); then compound 3.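

In this assay, cutting 2-hydroxy-2-methylpropyl back to ethyl gives a number 18.4 percentage points higher from compound 2 to compound 4 (beyond the scatter) and so shows that the low number of compound 2 goes with that particular group, not with any chain on this aromatic nitrogen. The step with methyl in place of hydrogen at the saturated chain carbon gives a number 9 percentage points lower from compound 1 to compound 4 (within the scatter) and stays within the scatter. Nothing measured here explains these steps.

Whether the hydroxyl or the branching accounts for the drop stays open. So does the place in this series of a plain isobutyl chain or a chain ending in an amine.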